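Methyl for hydrogen on the nitro-bearing ring of compound 3

A few compounds are considered here, and "the series" means these few. Any claim that something is new, unique, unknown or untested is made for them only; others in the source may bear on it.

Compound 3 `CNC(=O)c1ccccc1Sc1ccccc1[N+](=O)[O-]` carries the amide-bearing core with a nitro group on the second ring. Within the data shown here, in an in vitro assay on cells (kidney) for binding affinity to sodium-dependent dopamine transporter (Homo sapiens) (on this read-out lower numbers stand for stronger inhibition and higher numbers for weaker inhibition), compound 3 gives 969 nM, the only number in the set. Compound 1 `CCc1ccc(Sc2ccccc2CN(C)C)c(N)c1` reaches only a limit in this assay, > 2000 nM. Compound 2 `CN(C)Cc1ccccc1Sc1ccc(CCF)cc1N` likewise reaches only a limit, > 5000 nM. Among the measured compounds shown here, the single step between measured compounds, a step that the two limits leave unreadable from compound 1 to compound 2, cannot be read because the limit of > 2000 nM in this assay, at which 1 of the 3 values shown sits, and the limit of > 5000 nM in this assay, at which 1 of the 3 values shown sits, both stand at limits.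

Compound 4 `CNC(=O)c1ccccc1Sc1ccc(C)cc1[N+](=O)[O-]` differs from compound 3 by methyl in place of hydrogen on an aromatic carbon. For the measured compounds named here, no measured step concerns a methyl on an aromatic carbon, so no step size can be carried over; the change is small and the working assumption is a step within the scatter. The expected step is a 1.2-fold lower number from compound 3 to compound 4 (0.08 log units; within the scatter). Compound 4 is therefore expected to give about 800 nM in this assay, with a range from 300 nM to 2500 nM.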

Compound 4, inhibition constant: 698 nM
Compound 4: middle estimate off by 1.1-fold (0.06 log units), on the high side, and the stated range covers the measured number.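

The series now has its first readable step, a 1.4-fold lower number from compound 3 to compound 4 (0.14 log units; within the scatter), in this assay, for methyl in place of hydrogen on an aromatic carbon, meta to a nitro group and para to a large group. Among these compounds, the one earlier step cannot be read, both its ends being limits, so this pair gives the only step size available: at this position, a methyl does not move the read-out beyond the scatter. Nothing shown bears on the reason for this result.

From the compounds shown here alone, whether a methoxy group or a carboxylic acid at the same position would also stay within the scatter remains open. No compound pair shown differs in one place between the core of compound 3 and the core of compound 1, so those two cores stay uncompared.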